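Compound 1 to Compound 4: an Expected Cytotoxicity Value

The source may report more compounds than this note shows. Statements on the series, on what has been measured and on what is new or still open speak of the compounds shown alone.

Of the compounds shown here, three have been measured in an ADME assay on HUVEC cells (Homo sapiens) for cytotoxicity, read by MTT assay, with a stated time of 48 h; a lower number here means a stronger inhibitor, a higher number a weaker inhibitor. Compound 1 `Cc1ccc(NC(=S)OCCNC(=O)C(C)(C)Oc2ccc(Cl)cc2)cc1` gives 661000 nM in this assay. Compound 2 `O=C(Oc1ccc(-c2cc(=S)ss2)cc1)c1cccnc1` gives 562000 nM, and compound 3 `CC(C)(Oc1ccc(Cl)cc1)C(=O)Oc1ccc(C(N)=S)cc1` gives 755000 nM. Compound 1 stands second highest of the three numbers; its nearest neighbour is compound 3 and its furthest is compound 2, and both of those gaps lie within the scatter of repeated measurements, so the three compounds cannot be told apart on these numbers.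

Compound 4 `CC(C)(Oc1ccc(Cl)cc1)C(=O)NCCOC(=S)Nc1ccc([N+](=O)[O-])cc1Cl` has not yet been measured. It differs from compound 1 in one place: 2-chloro-4-nitrophenyl in place of 4-methylphenyl on an amide-type nitrogen. Among the measured compounds shown here, no measured pair shows this change, so its effect is not known from these data. Given that all three measured compounds sit so close together in this assay, the step is expected to stay within the scatter, with at most a slight lean toward a lower number. The step expected from compound 1 to compound 4 is a 1.3-fold lower number from compound 1 to compound 4 (0.12 log units; within the scatter). Compound 4 is therefore estimated at 500000 nM, with a range from 200000 nM to 1300000 nM.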

Compound 4, half-maximal inhibitory concentration: 729000 nM
Beside the measured number, compound 4's estimate is 1.5-fold (0.16 log units) below it, and the stated range covers the measured number.
By their numbers in this assay, from the lowest: compounds 2, 1, 4 and 3 (each within the scatter of the next).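

In this assay, 2-chloro-4-nitrophenyl in place of 4-methylphenyl on an amide-type nitrogen gives a 1.1-fold higher number from compound 1 to compound 4 (0.04 log units; within the scatter), and this is the first pair shown that differs in one place. The entering group has more heavy atoms and brings hydrogen-bond acceptors that the leaving group lacks, yet compound 1 and compound 4 cannot be told apart in this assay. Nothing available explains why the two numbers lie so close.

On these data alone, the chlorine and the nitro group enter together, so what each contributes alone stays open. As far as these compounds go, it is also open whether an amine or a carboxylic acid on the phenyl ring, or a longer chain on this nitrogen, would give a step beyond the scatter.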